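This account rests on a few compounds, and the source may have more. Where it says the series, first, only, none or still open, it means among the compounds named here.

Working notes on the series, values in a functional assay on MDA-MB-231 cells (Homo sapiens) for inhibition, read by CellTiter-Glo, with a stated time of 96 h; on this read-out lower numbers stand for higher toxicity in this test and higher numbers for lower toxicity in this test

- compound 1 `CC1=C(C(C)C(=O)NCCN2CCCC2)c2cc(F)ccc2/C1=C\c1ccc([S+](C)[O-])cc1`: 39300 nM
- compound 2 `CC1=C(C(C)C(=O)NCCN2CCNCC2)c2cc(F)ccc2/C1=C\c1ccc([S+](C)[O-])cc1`: > 50000 nM (a limit of the assay)
- compound 3 `CC1=C(C(C)C(=O)N2CCN(CCN(C)C)CC2)c2cc(F)ccc2/C1=C\c1ccc([S+](C)[O-])cc1`: > 50000 nM (a limit of the assay)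

Going by the values given here, compound 1 holds the only true number in this set, since the other two entries are limits. Compound 4 `CC1=C(C(C)C(=O)N2CCN(CCCN(C)C)CC2)c2cc(F)ccc2/C1=C\c1ccc([S+](C)[O-])cc1` is still unmeasured. It differs from compound 1 by 4-(3-(dimethylamino)propyl)piperazin-1-yl in place of (2-(pyrrolidin-1-yl)ethyl)amino on a carbonyl carbon.

Among the compounds with values here, three measured steps bear on this. One is an at least 1.2-fold higher number from compound 1 to compound 2 (0.10 log units; that floor lies within the scatter), and the remaining pair gives a step that the two limits leave unreadable from compound 2 to compound 3. The closest is an at least 1.2-fold higher number from compound 1 to compound 3 (0.10 log units; that floor lies within the scatter), where 4-(2-(dimethylamino)ethyl)piperazin-1-yl enters on the same carbonyl carbon. Resting on that step, a small upward move in this assay is expected, possibly none beyond the scatter, and the reading may again be only a limit. The expected step is a 1.3-fold higher number from compound 1 to compound 4 (0.10 log units; within the scatter). For compound 4 the estimate is 50000 nM, with an expected range of 30000 nM to 85000 nM.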

Compound 4, half-maximal cytotoxic concentration: > 50000 nM
Compound 4 ended at the assay's limit (the forecaster's own chance of this, stated with the estimate: 70%); the middle value lies on the limit itself.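

In this assay, 4-(3-(dimethylamino)propyl)piperazin-1-yl on the carbonyl carbon gives an at least 1.2-fold higher number from compound 1 to compound 4 (0.10 log units; that floor lies within the scatter). Compound 4 gives > 50000 nM, which is a limit of the assay, so (dimethylamino)methyl in place of dimethylamino on the saturated chain carbon does not bring the reading down to a number. The steps from compound 2 and compound 3 to compound 4 cannot be read, and compound 1 remains the only true number in the series: the limit of > 50000 nM in this assay, at which 3 of the 4 values shown sit.

From the compounds shown here alone, whether compound 2, compound 3 and compound 4 differ from one another in this assay stays open. Also open, going by these compounds, is how a morpholin-4-yl group or a (3-(pyrrolidin-1-yl)propyl)amino group on the same carbonyl carbon would read against compound 1.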